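This account rests on a few compounds, and the source may have more. Where it says the series, first, only, none or still open, it means among the compounds named here.

Working notes on the series, all read in a functional assay on HL-60 cells (Homo sapiens) for cytotoxicity, read by WST assay, with a stated time of 48 h; a higher number here means a weaker inhibitor, a lower number a stronger inhibitor. Compound 1 (`O[C@@H](c1ccccc1)[C@H]1CO[C@H](c2ccccc2)[C@@H](C/C=C/c2ccccc2)C1`) gives 7040 nM, compound 2 (`CCCCCC/C=C/C[C@H]1C[C@@H]([C@@H](O)c2ccccc2)CO[C@@H]1c1ccccc1`) gives 4990 nM, and compound 3 (`COc1cccc(/C=C/C[C@H]2C[C@@H]([C@@H](O)c3ccccc3)CO[C@@H]2c2ccccc2)c1`) gives 9620 nM. Compound 3 therefore stands within the scatter of both others, with a 1.4-fold higher number from compound 1 to compound 3 (0.14 log units; within the scatter) and a 1.9-fold higher number from compound 2 to compound 3 (0.29 log units; within the scatter).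

The change to compound 4 (`COc1ccccc1/C=C/C[C@H]1C[C@@H]([C@@H](O)c2ccccc2)CO[C@@H]1c1ccccc1`) is 2-methoxyphenyl in place of 3-methoxyphenyl on a double-bonded chain carbon bound to a double-bonded chain carbon. Within the data shown here, no measured step contains this exchange, so the evidence is indirect. The closest is the addition of methoxy, with a 1.4-fold higher number from compound 1 to compound 3 (0.14 log units; within the scatter). A much larger exchange on the same carbon also stayed small, with a 1.4-fold lower number from compound 1 to compound 2 (0.15 log units; within the scatter). Every measured step in the series lies within the scatter, and no step beyond the scatter is expected in this assay.

The expected change is a 1.3-fold lower number from compound 3 to compound 4 (0.11 log units; within the scatter), with no confident direction. For compound 4 the estimated value is 7500 nM, with an expected range of 4000 nM to 14000 nM.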

Compound 4, half-maximal inhibitory concentration: 10100 nM
The estimate for compound 4 lay 1.3-fold (0.13 log units) below the measured number; low and high end bracket the measured number.
By their numbers in this assay, from the lowest: compounds 2, 1, 3 and 4 (each within the scatter of the next, the first and the last beyond it).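

In this assay, 2-methoxyphenyl in place of 3-methoxyphenyl on a double-bonded chain carbon does not separate the pair (a 1.0-fold higher number from compound 3 to compound 4 (0.02 log units; within the scatter)), so these two placements of the methoxy cannot be told apart here. Methoxy in place of hydrogen on an aromatic carbon again stays within the scatter in this second placement (a 1.4-fold higher number from compound 1 to compound 4 (0.16 log units; within the scatter)). Against the hexyl compound, 2-methoxyphenyl gives the only step in the series beyond the scatter, and a modest one (a 2.0-fold higher number from compound 2 to compound 4 (0.31 log units; beyond the scatter)), while the matching 3-methoxyphenyl step stays within it (a 1.9-fold higher number from compound 2 to compound 3 (0.29 log units; within the scatter)), so the separation is thin.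

As far as these compounds go, whether an amine or a carboxylic acid on that aromatic ring, or a chain longer than hexyl, would move the number further remains open. No evidence is available to explain these numbers.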